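The source may report more compounds than this note shows. Statements on the series, on what has been measured and on what is new or still open speak of the compounds shown alone.

Of the compounds shown here, three that share one core have been tested in an ADME assay on Vero cells (Chlorocebus sabaeus) for cytotoxicity, read by resazurin assay, with a stated time of 3 days; on this read-out higher numbers stand for weaker inhibition and lower numbers for stronger inhibition. Compound 1 `CCCc1ccc(C(=O)Nc2cc3nc(C4CCCCC4)[nH]c3cc2N(C)C)cc1` gives only a limit there, > 100 ug/mL. Compound 2 `Cc1ccc(C(=O)Nc2cc3nc(C4CCCCC4)[nH]c3cc2N(C)C)cc1` also gives a limit, > 100 ug/mL. Compound 3 `CN(C)c1cc2[nH]c(C3CCCCC3)nc2cc1NC(=O)c1ccc(F)cc1` likewise gives a limit, > 100 ug/mL. Because all three values sit at the limit of > 100 ug/mL in this assay, at which 3 of the 3 values shown sit, none of the steps among them can be read: a step that the two limits leave unreadable from compound 1 to compound 2, a step that the two limits leave unreadable from compound 1 to compound 3 and a step that the two limits leave unreadable from compound 2 to compound 3 all have an unreadable size. Compound 3 therefore stands where the other two stand, at the limit of this assay, with no number of its own.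

Compound 4 `CN(C)c1cc2[nH]c(C3CCCCC3)nc2cc1NC(=O)c1ccc(OC(F)(F)F)cc1` has not yet been measured. It differs from compound 3 in one place: trifluoromethoxy in place of fluoro on an aromatic carbon. Within the data shown here, no measured step bears on this change, so no direction or size can be drawn from the data beyond the observation that every measured compound sits at the limit. Compound 4 is expected to give about 100 ug/mL, within a range of 50 ug/mL to 200 ug/mL, most likely again as a limit. The expected step of a number no higher from compound 3 to compound 4 (the limit leaves the size open) is therefore none beyond the scatter.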

Compound 4, half-maximal inhibitory concentration: > 100 ug/mL
Compound 4: no number, only a limit; the forecaster's own chance of this, stated with the estimate: 75%; the middle value lies on the limit itself.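

No step from compound 4 to compound 1, compound 2 or compound 3 can be read in this assay, since all four sit at one limit: the limit of > 100 ug/mL in this assay, at which 4 of the 4 values shown sit.

The compounds shown leave open whether any of these changes on the aromatic carbon shifts the read-out, and what actual value each compound has.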